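Bromo entering the 3-fluorophenyl group of compound 1

This account rests on a few compounds, and the source may have more. Where it says the series, first, only, none or still open, it means among the compounds named here.

Among the compounds with values here, compound 1 `COc1cc2ncnc(Nc3ccc(NC(=O)c4cccc(F)c4)cc3)c2cc1OC` stands at 13600 nM in a functional assay on MCF7 cells (Homo sapiens) for inhibition, read by MTT assay (a higher number here means a weaker inhibitor, a lower number a stronger inhibitor), the lowest of the two numbers so far, though its nearest neighbour is close. Compound 2 `COc1cc2ncnc(Nc3ccc(NC(=O)c4ccc(Cl)c(Cl)c4)cc3)c2cc1OC` gives 25000 nM in this assay, and the step of a 1.8-fold higher number from compound 1 to compound 2 (0.26 log units; within the scatter) lies within the scatter. Compound 3 `COc1cc2ncnc(Nc3ccc(NC(=O)c4cc(F)ccc4Br)cc3)c2cc1OC` is not yet measured; it differs from compound 1 by bromo in place of hydrogen on an aromatic carbon. Within the data shown here, only one measured step bears on this, the one on the same 3-fluorophenyl group on the carbonyl carbon, and it is small at a 1.8-fold higher number from compound 1 to compound 2 (0.26 log units; within the scatter). On that basis no step beyond the scatter is expected in this assay in either direction, with the data too thin to favour one. Compound 3 is therefore estimated at 13000 nM, within 5000 nM to 35000 nM. The expected step is a 1.0-fold lower number from compound 1 to compound 3 (0.02 log units; within the scatter).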

Compound 3, half-maximal inhibitory concentration: 26000 nM
The estimate for compound 3 lay 2.0-fold (0.30 log units) below the measured number; measured number inside the range.
By their numbers in this assay, from the lowest: compounds 1, 2 and 3 (each within the scatter of the next).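

In this assay, bromo on the aromatic carbon ortho to a large group and para to the fluoro group gives a 1.9-fold higher number from compound 1 to compound 3 (0.28 log units; within the scatter), so this position accepts a bromo with no step beyond the scatter. The 2-bromo-5-fluorophenyl and 3,4-dichlorophenyl groups on the carbonyl carbon also read alike, at a 1.0-fold higher number from compound 2 to compound 3 (0.02 log units; within the scatter), and the three groups on that carbon are not separated in this assay. No measurement is available that could account for these readings.

Open, on these data alone, is whether an amine or a carboxylic acid on the same aromatic carbon would give a step beyond the scatter. Also open, as far as these compounds go, is whether bromo at this place reads the same on a phenyl group without the fluoro group.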